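Compound 2 losing its (4-hydroxybenzyl)amino group

This account rests on a few compounds, and the source may have more. Where it says the series, first, only, none or still open, it means among the compounds named here.

In a functional assay on SW480 cells (Homo sapiens) for inhibition, read by CCK-8 assay, with a stated time of 4 days (a lower number here means a stronger inhibitor, a higher number a weaker inhibitor), compound 1 (`COc1cc(C(=O)O)ccc1NC(=O)[C@@H]1N[C@@H](CC(C)(C)C)[C@](CNCc2ccncc2)(c2ccc(Cl)cc2F)[C@H]1c1cccc(Cl)c1F`) gives 2820 nM and compound 2 (`COc1cc(C(=O)O)ccc1NC(=O)[C@@H]1N[C@@H](CC(C)(C)C)[C@](CNCc2ccc(O)cc2)(c2ccc(Cl)cc2F)[C@H]1c1cccc(Cl)c1F`) gives 3750 nM, so the two values lie within the scatter of each other. Compound 3 (`COc1cc(C(=O)O)ccc1NC(=O)[C@@H]1N[C@@H](CC(C)(C)C)[C@](C)(c2ccc(Cl)cc2F)[C@H]1c1cccc(Cl)c1F`) changes compound 2 as follows: hydrogen in place of (4-hydroxybenzyl)amino on a saturated chain carbon bound to a saturated ring carbon. This places hydrogen in place of (4-hydroxybenzyl)amino on a saturated chain carbon bound to a saturated ring carbon, which leaves methyl. Among the compounds with values here, only one measured step bears on this, a 1.3-fold higher number from compound 1 to compound 2 (0.12 log units; within the scatter), and it exchanges 4-hydroxyphenyl for pyridin-4-yl while the amine stays. Within the data shown here, no measured compound lacks the amine, so that step is a weak guide and the range stays wide. The estimated step is a 1.1-fold higher number from compound 2 to compound 3 (0.03 log units; within the scatter), and none beyond the scatter is expected. For compound 3 the expected value is 4000 nM, with an estimated range of 1500 nM to 12000 nM.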

Compound 3, half-maximal inhibitory concentration: 8190 nM
Beside the measured number, compound 3's estimate is 2.0-fold (0.31 log units) below it; the measured number falls inside the stated range.
By their numbers in this assay, from the lowest: compounds 1 and 2 (each within the scatter of the next); then compound 3.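

In this assay, removing the (4-hydroxybenzyl)amino group brings a 2.2-fold higher number from compound 2 to compound 3 (0.34 log units; beyond the scatter), and removing the ((pyridin-4-yl)methyl)amino group brings a 2.9-fold higher number from compound 1 to compound 3 (0.46 log units; beyond the scatter). Where the exchange of 4-hydroxyphenyl and pyridin-4-yl stayed within the scatter, these steps show that the number in this assay does respond to this place, on a saturated chain carbon bound to a saturated ring carbon: both amine-bearing compounds give lower numbers than the methyl compound, and neither goes against this. No measured evidence bears on why the number rises on this change.

On these data alone, what remains open is whether the amine nitrogen alone accounts for the steps or whether the aromatic ring on it is also needed. A plain aminomethyl group, or a hydroxymethyl group in the same place, would separate these two readings.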